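Replacing the ethoxyphenyl arm of compound 1 with a methylpyridyl

This account rests on a few compounds, and the source may have more. Where it says the series, first, only, none or still open, it means among the compounds named here.

Compound 1 `CCOc1ccccc1-c1ccc(-c2nc3cnccc3c(N[C@H](CC)C(N)=O)c2C#N)cc1` is the reference point of this small set. In a physicochemical assay for lipophilicity, read by HPLC, at pH 7.5 (a higher number here means a more lipophilic compound, a lower number a more polar compound), compound 1 gives 3; compound 2 `CCCCC(Nc1c(C#N)c(-c2ccc(-c3ccccc3OCC)cc2)nc2cnccc12)C(N)=O` gives 3.6 and compound 3 `CCOc1ccccc1-c1ccc(-c2nc3cnccc3c(N[C@@H]3CCOC3=O)c2C#N)cc1` gives 2.7, so compound 1 stands second highest of the three, with compound 3 nearest (a number 0.30 log units lower from compound 1 to compound 3 (within the scatter)) and compound 2 furthest (a number 0.60 log units higher from compound 1 to compound 2 (beyond the scatter)). All three measured steps, including a number 0.90 log units lower from compound 2 to compound 3 (beyond the scatter), alter only the group on the ring nitrogen; none of them touches the biaryl end.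

Compound 4 `CC[C@@H](Nc1c(C#N)c(-c2ccc(-c3ccncc3C)cc2)nc2cnccc12)C(N)=O` differs from compound 1 at that untouched end: 3-methylpyridin-4-yl in place of 2-ethoxyphenyl on an aromatic carbon. Going by the values given here, no measured step bears directly on this change, so the expectation rests on the change alone and on compound 1 as anchor. A lowering beyond the scatter is expected, of about a number 1.00 log units lower from compound 1 to compound 4 (beyond the scatter) in this assay.

For compound 4 the estimate in this assay is therefore 2, with a range from 1.4 to 2.6.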

Compound 4, distribution coefficient: 2
Compound 4: the middle estimate sits on the measured number at the digits printed; measured number inside the range.
By their numbers in this assay, from the lowest: compound 4; then compounds 3 and 1 (each within the scatter of the next); then compound 2.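

Going by these compounds alone, the biaryl end of the series moves the reading in this assay, which the earlier steps could not show because they altered only the group on the ring nitrogen: 3-methylpyridin-4-yl in place of 2-ethoxyphenyl gives a number 1.00 log units lower from compound 1 to compound 4 (beyond the scatter). This single step changes two things at once, a carbon-only aromatic ring giving way to a ring with one hetero atom and 9 heavy atoms giving way to 7, and the data cannot separate the two. No measurement here accounts for the size of the step.

A 2-methylphenyl or a 3-methylpyridin-2-yl at this place could begin to separate the hetero atom from the loss of the ethoxy group. Also open, from the compounds shown here alone, is whether a similar step appears with 1-carbamoylpentyl or 2-oxooxolan-3-yl on the nitrogen.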